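Extending the ether chain of compound 2 with a basic amine

The source may report more compounds than this note shows. Statements on the series, on what has been measured and on what is new or still open speak of the compounds shown alone.

The measured compounds, with their results in an assay on isolated protein for inhibition of cathepsin S (Homo sapiens), read by fluorescence; on this read-out higher numbers stand for weaker inhibition and lower numbers for stronger inhibition:
- Compound 1 `N#Cc1nc(-c2ccc(OCCCO)c(C(F)(F)F)c2)cc2[nH]cnc12` gives 63 nM.
- Compound 2 `CCOc1ccc(-c2cc3c(ncn3C)c(C#N)n2)cc1C(F)(F)F` gives 40 nM.
- Compound 3 `Cn1cnc2c(C#N)nc(-c3ccc(OCCN4CCCC4=O)c(C(F)(F)F)c3)cc21` gives 7.8 nM.

Compound 2 stands second highest of these three numbers. Its nearest neighbour is compound 1, whose value lies within the usual scatter of compound 2, so the two cannot be told apart. Compound 3 lies furthest away: the step of a 5.1-fold lower number from compound 2 to compound 3 (0.71 log units; beyond the scatter) came from placing 2-oxopyrrolidin-1-yl in place of hydrogen on a saturated chain carbon, two bonds along the chain from an oxygen on an aromatic ring.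

Compound 4 `CN(C)CCCOc1ccc(-c2cc3c(ncn3C)c(C#N)n2)cc1C(F)(F)F` changes compound 2 at exactly that same spot: (dimethylamino)methyl in place of hydrogen on a saturated chain carbon, two bonds along the chain from an oxygen on an aromatic ring. For the measured compounds named here, only one measured step bears on this change, the one from compound 2 to compound 3, and it was modest but beyond the scatter. The group entering here is smaller than the ring that entered in compound 3, and it carries no carbonyl, so the earlier step is only a rough guide. A lowering of similar or slightly smaller size is therefore expected in this assay, written as the step of a 2.7-fold lower number from compound 2 to compound 4 (0.43 log units; beyond the scatter). Compound 4 is estimated at 15 nM, with a range from 5 nM to 45 nM.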

Compound 4, half-maximal inhibitory concentration: 41 nM
Estimate against measurement, compound 4: 2.7-fold (0.44 log units) below; the measured number falls inside the stated range.
By their numbers in this assay, from the lowest: compound 3; then compounds 2, 4 and 1 (each within the scatter of the next).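

In this assay, the step of a 1.0-fold higher number from compound 2 to compound 4 (0.01 log units; within the scatter) shows that compound 2 and compound 4 cannot be told apart, so the longer chain with its dimethylamino group can be carried at this position with no measurable effect on the number. The earlier step to compound 3 could have suggested that extending the chain at this carbon was enough to lower the number, but the step of a 5.3-fold higher number from compound 3 to compound 4 (0.72 log units; beyond the scatter) argues against that: with the same attachment point and two different groups, what matters in this pair is the group that enters, not the extension alone. No measurement shown explains why 2-oxopyrrolidin-1-yl and (dimethylamino)methyl behave differently here.

As far as these compounds go, it remains open whether the carbonyl or the ring of the 2-oxopyrrolidin-1-yl group accounts for the lower number of compound 3, which a pyrrolidin-1-yl ring without the carbonyl or an open-chain acetamide at the same carbon could help to separate. From the compounds shown here alone, it is also open whether a morpholin-4-yl ring, or a shorter 2-(dimethylamino)ethoxy chain, would give a number closer to that of compound 3 or to that of compound 4.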